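The compounds below may be only part of what the source reports. "The series", "measured", "known", "first", "only" and "open" are said of these compounds alone.

Measured compounds: compound 1 `Cc1ccc(S(=O)(=O)/N=C(/CCNC2=CC(=O)c3ccccc3C2=O)Nc2ccc(Cl)cc2)cc1` gives 29900 nM in a functional assay on A549 cells (Homo sapiens) for cytotoxicity, read by MTT assay, with a stated time of 48 h; a higher number here means a weaker inhibitor, a lower number a stronger inhibitor; compound 2 `COc1ccc(N/C(CCNC2=CC(=O)c3ccccc3C2=O)=N\S(=O)(=O)c2ccc(C)cc2)c(OC)c1` gives 126000 nM.

Going by the values given here, compound 2 stands at the highest number of the two, with compound 1 as the only neighbour, and the step of a 4.2-fold higher number from compound 1 to compound 2 (0.62 log units; beyond the scatter) is the sole measured change bearing on the question. Compound 3 `Cc1ccc(S(=O)(=O)/N=C(/CCNC2=CC(=O)c3ccccc3C2=O)NCc2ccccc2)cc1` differs from compound 2 by benzyl in place of 2,4-dimethoxyphenyl on an amine nitrogen. Among the compounds with values here, since the only measured aryl swap moved the number modestly, a step of comparable size in the opposite direction is expected, a 2.5-fold lower number from compound 2 to compound 3 (0.40 log units; beyond the scatter). Compound 3 is therefore estimated at 50000 nM, within a range of 15000 nM to 200000 nM.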

Compound 3, half-maximal inhibitory concentration: 7410 nM
Estimate against measurement, compound 3: 6.7-fold (0.83 log units) above; the measured number lies below the stated range.
By their numbers in this assay, from the lowest: compound 3; then compound 1; then compound 2.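

At this amine nitrogen, benzyl gives the lowest number of the three in this assay, with a 17-fold lower number from compound 2 to compound 3 (1.23 log units; beyond the scatter) and a 4.0-fold lower number from compound 1 to compound 3 (0.61 log units; beyond the scatter). The two substituted phenyl groups alone did not show that a change at this place could reach so far, or that a group from outside that pair could pass both. Nothing shown explains these steps. Going by these compounds, it remains open whether an unsubstituted phenyl or a longer phenethyl chain on the same nitrogen would follow benzyl, and whether a chlorine or methoxy on the benzyl ring would keep its lower number.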